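The compounds below may be only part of what the source reports. "The series", "measured", "known", "first", "only" and "open" are said of these compounds alone.

Measured so far, in a toxicity assay on Vero C1008 cells (Chlorocebus sabaeus) for cytotoxicity, read by neutral red uptake, with a stated time of 5 days; on this read-out lower numbers stand for higher toxicity in this test and higher numbers for lower toxicity in this test:
compound 1 `C[C@H](NC(=O)C(c1cccnc1)N(C(=O)c1ccco1)c1ccc(C2CCCCC2)cc1)c1ccccc1`: 9610 nM
compound 2 `CC(C)(C)CC(C)(C)NC(=O)C(c1cccnc1)N(C(=O)c1ccco1)c1ccc(-c2ccccc2)cc1`: 148000 nM

For the measured compounds named here, of the two, compound 2 stands highest; the only other compound, compound 1, gives a lower number, and that gap lies beyond the scatter. Compound 3 `O=C(NCCCc1ccccc1)C(c1cccnc1)N(C(=O)c1ccco1)c1ccc(-c2ccccc2)cc1` has not yet been tested. It differs from compound 2 in one place: 3-phenylpropyl in place of 1,1,3,3-tetramethylbutyl on an amide-type nitrogen. Going by the values given here, no step between measured compounds isolates this change, so compound 1 serves only as a distant reference point. Compound 3 is expected to move toward a lower number, with a step of a 3.0-fold lower number from compound 2 to compound 3 (0.47 log units; beyond the scatter) in this assay. The estimated value of compound 3 is 50000 nM, within 15000 nM to 160000 nM.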

Compound 3, half-maximal cytotoxic concentration: > 200000 nM
Compound 3: only a limit was reported; the forecaster's own chance of this, stated with the estimate: 10%; at least 4.0-fold (0.60 log units) between middle value and limit.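

In this assay compound 3 gives only a limit, > 200000 nM, and not a number. For the compounds shown here, on this amide-type nitrogen, 3-phenylpropyl in place of 1,1,3,3-tetramethylbutyl gives an at least 1.3-fold higher number from compound 2 to compound 3 (0.13 log units; that floor lies within the scatter), so bringing in an aromatic ring at the end of the chain produces no lower number, something the earlier compounds could not show. The true size of this step cannot be read because the result rests on a limit: the limit of > 200000 nM in this assay, at which 1 of the 3 values shown sits.

As far as these compounds go, whether any group on this nitrogen gives a lower number remains open. A benzyl group or a propyl chain ending in an amine would test this.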